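The source may report more compounds than this note shows. Statements on the series, on what has been measured and on what is new or still open speak of the compounds shown alone.

Measured in a functional assay on MCF7 cells (Homo sapiens) for antiproliferative activity, read by MTT assay, with a stated time of 48 h; on this read-out higher numbers stand for weaker inhibition and lower numbers for stronger inhibition:
- Compound 1 `CCn1c(C(=O)N(C)CC(=O)O)ccc1C(CC)(CC)c1ccc(OCCC(O)(CC)CC)c(C)c1`: 79 nM
- Compound 2 `CCn1c(C(=O)NC(CC(=O)O)C(=O)OC)ccc1C(CC)(CC)c1ccc(OCCC(O)(CC)CC)c(C)c1`: 10200 nM

Of these two, compound 2 has the higher number, 10200 nM, and so is the weaker inhibitor. Compound 3 `CCn1c(C(=O)NC(C)C(=O)O)ccc1C(CC)(CC)c1ccc(OCCC(O)(CC)CC)c(C)c1` differs from it in one place: a group of 5 heavy atoms (3 carbon, 2 oxygen; no ring) in place of a group of 9 heavy atoms (5 carbon, 4 oxygen; no ring), on an amide-type nitrogen. The group that enters is 1-carboxyethyl.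

For the measured compounds named here, only one measured step bears on this change: a 130-fold higher number from compound 1 to compound 2 (2.11 log units; beyond the scatter). That large step altered the same part of the molecule and ended in the larger group now being removed. The group in compound 3 is smaller, so part of that loss may be recovered, though probably not all of it, as compound 3 is not identical to compound 1. In this assay, the expected change is a clearly lower number, with an estimated step of a 17-fold lower number from compound 2 to compound 3 (1.23 log units; beyond the scatter). The estimate for compound 3 is 600 nM, with an expected range of 100 nM to 4000 nM.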

Compound 3, half-maximal inhibitory concentration: 19700 nM
Compound 3: middle estimate off by 33-fold (1.52 log units), on the low side, and the stated range ends below it.
By their numbers in this assay, from the lowest: compound 1; then compounds 2 and 3 (each within the scatter of the next).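

In this assay, the smaller 1-carboxyethyl group on the amide-type nitrogen brings no recovery: the result is a 1.9-fold higher number from compound 2 to compound 3 (0.29 log units; within the scatter), so group size alone does not separate compound 2 from compound 1. The contrast with compound 1 stands out instead, as (1-carboxyethyl)amino in place of (carboxymethyl)(methyl)amino on a carbonyl carbon gives a 250-fold higher number from compound 1 to compound 3 (2.40 log units; beyond the scatter), even though both groups end in a carboxylic acid. Among these compounds, high potency is seen only with (carboxymethyl)(methyl)amino, and nothing available explains that difference.

On these data alone, compounds 1 and 3 differ in where a methyl group sits, so it remains open whether the gain depends on the substituted amide nitrogen or on the unbranched chain. Plain (carboxymethyl)amino and (1-carboxyethyl)(methyl)amino groups would help separate these two features, while a primary amide in place of the carboxylic acid would test the role of the acid.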